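This account rests on a few compounds, and the source may have more. Where it says the series, first, only, none or still open, it means among the compounds named here.

Compound 1 `COc1cccc(F)c1CNC(=O)c1[nH]c2ccc(Cl)cc2c1S(=O)(=O)c1cc(C)cc(C)c1`: > 49900 nM (a limit of the assay)
Compound 2 `Cc1cc(C)cc(S(=O)(=O)c2c(C(=O)Nc3ccnc(C#N)c3)[nH]c3ccc(Cl)cc23)c1`: 6840 nM

For the measured compounds named here, in an ADME assay on MT4 cells (Homo sapiens) for cytotoxicity, read by MTT assay (on this read-out higher numbers stand for lower toxicity in this test and lower numbers for higher toxicity in this test), compound 2 gives 6840 nM, the only exact number available so far. Compound 1 is recorded only as a limit, > 49900 nM, and this is the limit noted in the limit of > 49900 nM in this assay, at which 1 of the 2 values shown sits.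

The next compound to be tested is compound 3 `Cc1cc(C)cc(S(=O)(=O)c2c(C(=O)NCC(=O)NCc3ccco3)[nH]c3ccc(Cl)cc23)c1`. It carries (((furan-2-yl)methyl)carbamoyl)methyl in place of 2-cyanopyridin-4-yl on an amide-type nitrogen.

Going by the values given here, only one measured step bears on this change, an at least 7.2-fold lower number from compound 1 to compound 2 (0.86 log units; beyond the scatter). That step put 2-cyanopyridin-4-yl on the same nitrogen in place of 2-fluoro-6-methoxybenzyl, and it went with a clear drop in the number. Among the compounds with values here, compound 3 gives up that same group, so a move back towards higher numbers seems likely, though its incoming group differs from the one in compound 1 and a single step is thin support. The expected change is a 3.7-fold higher number from compound 2 to compound 3 (0.56 log units; beyond the scatter), which is upward and of similar order to the measured step. A reading reported only as a limit is also expected to be quite possible. For compound 3 the estimate is 25000 nM, with an expected range of 8000 nM to 50000 nM.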

Compound 3, half-maximal cytotoxic concentration: > 50000 nM
Compound 3: a limit, no number (the forecaster's own chance of this, stated with the estimate: 45%); middle value at least 2.0-fold (0.30 log units) away from the limit.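

Replacing 2-cyanopyridin-4-yl with (((furan-2-yl)methyl)carbamoyl)methyl on the amide-type nitrogen gives an at least 7.3-fold higher number from compound 2 to compound 3 (0.86 log units; beyond the scatter) in this assay, so the low number of compound 2 now stands against two different groups at this position rather than one. Compound 3 is recorded as a limit of the assay and not as a number: the limit of > 50000 nM in this assay, at which 1 of the 3 values shown sits. Compound 1 and compound 3 both have a saturated chain carbon bound to the amide-type nitrogen, whereas compound 2 has its aromatic ring there, and the step from compound 1 to compound 3 cannot be read.

On these data alone, with only these three compounds, it stays open whether the lower number in compound 2 goes with the nitrile, with the six-membered aromatic ring, or with the missing saturated chain carbon. As far as these compounds go, an unsubstituted pyridin-4-yl, a plain phenyl or a (2-cyanopyridin-4-yl)methyl on the same nitrogen would separate these possibilities, and how far compound 1 and compound 3 lie beyond their limits also remains unknown.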